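The source may report more compounds than this note shows. Statements on the series, on what has been measured and on what is new or still open speak of the compounds shown alone.

Working notes on the series in a functional assay on Caco-2 cells (Homo sapiens) for cytotoxicity, with a stated time of 48 h; a higher number here means a weaker inhibitor, a lower number a stronger inhibitor: compound 1 `COc1cc(O)c(C(=O)/C=C/c2ccc(F)cc2)c(OC)c1` gives 9200 nM, compound 2 `COc1cc(OC)c(C(=O)/C=C/c2ccccc2OC)c(OC)c1` gives 4500 nM and compound 3 `COc1cc(OC)c(C(=O)/C=C/c2ccccc2SC)c(OC)c1` gives 8800 nM. Compound 3 lies within the scatter of both other compounds, so no rank can be given to it.

Next is compound 4 `COc1cccc(/C=C/C(=O)c2c(OC)cc(OC)cc2OC)c1`, with this change from compound 3: 3-methoxyphenyl in place of 2-(methylsulfanyl)phenyl on a double-bonded chain carbon bound to a double-bonded chain carbon. In words, 3-methoxyphenyl stands in place of 2-(methylsulfanyl)phenyl on a double-bonded chain carbon bound to a double-bonded chain carbon.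

Going by the values given here, the one measured step that bears on this is a 2.0-fold higher number from compound 2 to compound 3 (0.29 log units; within the scatter), with methylsulfanyl in place of methoxy on an aromatic carbon. It lies within the scatter. Among the compounds with values here, no measured compound carries the 3-methoxyphenyl group, so the data give no direct reading of it. Read in reverse, that step points weakly towards a lower number in this assay, and nothing beyond the scatter is expected. The expected step is a 1.5-fold lower number from compound 3 to compound 4 (0.17 log units; within the scatter). Compound 4 is estimated at 6000 nM, with an expected range of 2000 nM to 18000 nM.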

Compound 4, half-maximal inhibitory concentration: 3900 nM
For compound 4 the middle estimate is 1.5-fold (0.19 log units) above the measured one; measured number inside the range.
By their numbers in this assay, from the lowest: compounds 4, 2, 3 and 1 (each within the scatter of the next, the first and the last beyond it).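

In this assay, going by these compounds alone, a 2.3-fold lower number from compound 3 to compound 4 (0.35 log units; beyond the scatter) is the first step to lie beyond the scatter, if only modestly, so replacing the group on a double-bonded chain carbon bound to a double-bonded chain carbon can register in this read-out. By contrast, a 1.2-fold lower number from compound 2 to compound 4 (0.06 log units; within the scatter) lies within the scatter, so 3-methoxyphenyl and 2-methoxyphenyl cannot be told apart here. No measured property bears on these results, and the data offer no explanation for them.

From the compounds shown here alone, whether an amine or a carboxylic acid in place of the methoxy group of 3-methoxyphenyl would give a step beyond the scatter from compound 4 remains open. Compound 1 differs from the other compounds in more than one place, so its separate changes cannot be read.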